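A few compounds are considered here, and "the series" means these few. Any claim that something is new, unique, unknown or untested is made for them only; others in the source may bear on it.

Of the compounds shown here, two have been measured in an ADME assay on microsomes from liver (Homo sapiens) for metabolic stability, read by LC-MS, using NADPH, with a stated time of 10 min, tested at 0.1 uM; on this read-out lower numbers stand for slow clearance and higher numbers for fast clearance. Compound 1 `Cc1ccnc(N2C(=O)CSC2c2cccc(C(=O)NCCCCn3cccn3)c2)c1` gives 129 mL.min-1.g-1 in this assay, while compound 2 `O=C(NCCCCc1ccccc1)c1cccc(C2SCC(=O)N2c2cccc(-c3c[nH]nn3)c2)c1` gives 261 mL.min-1.g-1 in this assay. Compound 2 thus has the higher of the two numbers, and its gap to compound 1 lies beyond the usual scatter of the measurement.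

The step under consideration leads from compound 2 to compound 3 `O=C(NCCCCc1ccccc1)c1cccc(C2SCC(=O)N2c2ccc(C3CC3)cc2)c1`, which has not yet been measured. The change is a group of 9 heavy atoms (9 carbon; one three-membered non-aromatic ring of carbon only, one six-membered aromatic ring of carbon only) in place of a group of 11 heavy atoms (8 carbon, 3 nitrogen; one five-membered aromatic ring with 3 hetero atoms, one six-membered aromatic ring of carbon only), on an amide-type nitrogen in a ring. Within the data shown here, no directly comparable step between measured compounds is available, so the expectation rests on the structural change alone.

A shift toward faster clearance is expected, with the step of a 1.5-fold higher number from compound 2 to compound 3 (0.16 log units; within the scatter) reaching beyond the scatter. Compound 3 is therefore estimated at 380 mL.min-1.g-1 in this assay, most likely falling between 190 mL.min-1.g-1 and 760 mL.min-1.g-1.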

Compound 3, intrinsic clearance in microsomes: 811 mL.min-1.g-1
Estimate against measurement, compound 3: 2.1-fold (0.33 log units) below, outside the stated range (above it).
By their numbers in this assay, from the lowest: compound 1; then compound 2; then compound 3.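

In this assay the group on the amide-type nitrogen in a ring matters: 4-cyclopropylphenyl, in place of the group with a five-membered aromatic ring with 3 hetero atoms, gives a 3.1-fold higher number from compound 2 to compound 3 (0.49 log units; beyond the scatter) and so moves toward faster clearance. Compound 1 and compound 2 differ in more than one place, so they could not show the effect of this position alone. No measurement shown gives a reason for this rise.

This single step cannot separate the loss of the five-membered ring from the arrival of the cyclopropyl group. Going by these compounds, a plain phenyl group, or a phenyl group carrying a carboxylic acid or an amine, would be needed to tell these apart, and whether the same swap acts alike with other amide side chains also remains open.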